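The source may report more compounds than this note shows. Statements on the series, on what has been measured and on what is new or still open speak of the compounds shown alone.

Compound 1 `OC1C[C@@H]2CCCC[C@@H]2[C@H]1/C=C/c1ccc(-c2cccc(F)c2)cn1`: 220 nM
Compound 2 `CCOC(=O)NC1C[C@@H]2CCCC[C@@H]2[C@H]1/C=C/c1ccc(-c2cccc(F)c2)cn1`: 2000 nM

In an assay on cell membranes for displacement of a labelled ligand from proteinase-activated receptor 1 (Homo sapiens), read by scintillation counting, with a stated time of 60 min (a lower number here means a stronger inhibitor, a higher number a weaker inhibitor), compound 1 gives 220 nM, while compound 2 gives 2000 nM. The only step among these two, a 9.1-fold higher number from compound 1 to compound 2 (0.96 log units; beyond the scatter), comes from putting (ethoxycarbonyl)amino in place of hydroxy on a saturated ring carbon. Compound 2 therefore stands with the higher of the two numbers in this assay.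

Compound 3 `CC(=O)NC1C[C@@H]2CCCC[C@@H]2[C@H]1/C=C/c1ccc(-c2cccc(F)c2)cn1` keeps the core of compound 2 and differs from it only by methyl in place of ethoxy on a carbonyl carbon. Going by the values given here, no measured step follows this kind of change: the one step known, from compound 1 to compound 2, exchanged the whole group on the ring carbon, and says nothing about trimming the group that sits on the carbonyl carbon beyond the amide-type nitrogen. The change is small and leaves the rest of compound 2 intact, so in this assay a step from compound 2 to compound 3 of no size beyond the scatter is expected, with wide uncertainty in either direction, a 1.3-fold lower number from compound 2 to compound 3 (0.12 log units; within the scatter). Compound 3 is thus estimated at 1500 nM, with a range from 500 nM to 5000 nM.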

Compound 3, half-maximal inhibitory concentration: 53 nM
Estimate against measurement, compound 3: 28-fold (1.45 log units) above; the measured number lies below the stated range.
By their numbers in this assay, from the lowest: compound 3; then compound 1; then compound 2.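

In this assay, the group on the carbonyl carbon proves decisive: with the rest of the molecule unchanged, methyl in place of ethoxy gives a 38-fold lower number from compound 2 to compound 3 (1.58 log units; beyond the scatter), a large step from a change of only a few heavy atoms. The earlier loss on replacing hydroxy with (ethoxycarbonyl)amino, a 9.1-fold higher number from compound 1 to compound 2 (0.96 log units; beyond the scatter), therefore cannot be read as a penalty for any nitrogen-linked group on the saturated ring carbon, since acetamido in place of hydroxy moves the other way, with a 4.2-fold lower number from compound 1 to compound 3 (0.62 log units; beyond the scatter). Nothing shown here explains why ethoxy and methyl differ so sharply at this position.

The compounds shown leave open whether the difference follows the length of the group or the oxygen of ethoxy, a question that methoxy and ethyl on the same carbonyl carbon would separate. They also leave open whether the carbonyl is needed at all, which a free amine or a methanesulfonamide on the saturated ring carbon would test against acetamido.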